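The source may hold more compounds than are shown below. What is called first, only, known or untested is meant among the compounds shown, and "the series" means these compounds.

Compound 1 `CC(C)[C@@H]1CC[C@@H](C)C[C@@]12N(C)C(=O)[C@@H]1[C@H]3C(=O)NC(=O)[C@H]3ON12`: 25.9%
Compound 2 `CC(C)[C@@H]1CC[C@@H](C)C[C@@]12N(C)C(=O)[C@@H]1[C@H]3C(=O)N(c4ccc(Cl)cc4)C(=O)[C@H]3ON12`: 47.5%

In a functional assay, read by spectrophotometry, with a stated time of 2 h, tested at 0.5 mg/mL (on this read-out higher numbers stand for a stronger effect at the one concentration tested and lower numbers for a weaker effect), compound 2 stands highest of the two measured compounds, with compound 1 nearest and well separated beyond the scatter. Compound 3 `COc1ccc(N2C(=O)[C@H]3[C@H](ON4[C@@H]3C(=O)N(C)[C@@]43C[C@H](C)CC[C@H]3C(C)C)C2=O)cc1` differs from compound 2 in one place: methoxy in place of chloro on an aromatic carbon. Within the data shown here, the only measured step, a number 21.6 percentage points higher from compound 1 to compound 2 (beyond the scatter), concerns 4-chlorophenyl in place of hydrogen, not methoxy in place of chloro, so it offers no direct guide. With nothing bearing on this exchange, a step of a number 2.5 percentage points lower from compound 2 to compound 3 (within the scatter) is expected, within the scatter. Compound 3 is estimated at 45%, expected between 30% and 60%.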

Compound 3, a percentage reported as activity, at one concentration (the size of the read-out at that concentration, not a potency): 44.5%
Beside the measured number, compound 3's estimate is 0.5 percentage points above it; the measured number falls inside the stated range.
By their numbers in this assay, from the lowest: compound 1; then compounds 3 and 2 (each within the scatter of the next).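

Exchanging chloro for methoxy on the aromatic ring leaves the read-out in this assay essentially unchanged (a number 3 percentage points lower from compound 2 to compound 3 (within the scatter)), so these two groups cannot be told apart at this position. Putting 4-methoxyphenyl in place of the hydrogen on the ring's amide-type nitrogen also gives a clear rise (a number 18.6 percentage points higher from compound 1 to compound 3 (beyond the scatter)), so the rise is not limited to 4-chlorophenyl. Nothing available explains either result.

Still open, as far as these compounds go, is whether an amine or a carboxylic acid on the aromatic ring would give a similar read-out. Also open, from the compounds shown here alone, is whether an unsubstituted phenyl or a simple butyl chain on that nitrogen would do the same.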